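The compounds below may be only part of what the source reports. "The series", "measured", "known", "first", "only" and "open" are said of these compounds alone.

Compound 1, `C=CCn1ncc2ccc(N/C(C)=C3\C(=O)C=C(C)OC3=O)cc21`, in an ADME assay on RAW264.7 cells (Mus musculus) for cytotoxicity, read by resazurin assay, with a stated time of 48 h (a lower number here means that less compound is tolerated, a higher number that more compound is tolerated), gives a result that is a limit of the assay, > 100000 nM.
Compound 2, `CCn1nc(Cl)c2ccc(N/C(C)=C3\C(=O)C=C(C)OC3=O)cc21`, in this assay gives 6230 nM.

Among the two results shown, compound 2 holds the only number; the other result is a limit and not a number. In this assay compound 2 thus stands alone as a measured value. For compound 1 the outcome is described by the limit of > 100000 nM in this assay, at which 1 of the 2 values shown sits, and nothing more is said of it than that it is a limit. Compound 3, `C=CCn1nc(Cl)c2ccc(N/C(C)=C3\C(=O)C=C(C)OC3=O)cc21`, is not yet measured. It differs from compound 2 by vinyl in place of methyl on a saturated chain carbon bound to an aromatic nitrogen; cut one bond further out, the same change reads ethyl to allyl. Going by the values given here, no step between measured compounds is available to size this change, and compound 1, which carries the allyl group but lacks the chlorine, is linked to compound 3 by no counted step, so only its limit can be stated. The step of a 1.6-fold higher number from compound 2 to compound 3 (0.21 log units; within the scatter) is expected to be modest, toward a higher number, and not far beyond the scatter. Compound 3 is expected to give 10000 nM, between 3000 nM and 50000 nM.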

Compound 3, half-maximal cytotoxic concentration: > 100000 nM
Compound 3: no number, only a limit; the forecaster's own chance of this, stated with the estimate: 20%; middle value at least 10-fold (1.00 log units) from the limit.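

In this assay, going by these compounds alone, the change of ethyl to allyl at this place, on a saturated chain carbon bound to an aromatic nitrogen, gives an at least 16-fold higher number from compound 2 to compound 3 (1.20 log units; beyond the scatter), so with the chlorine kept, this small change is enough to produce a large step beyond the scatter, which no earlier pair could size. The step carries only a lower bound, since the result of compound 3 is a limit and not a number. Chloro in place of hydrogen on an aromatic carbon, the change that links compound 1 to compound 3, cannot be read, and of the compounds shown only compound 2, with ethyl, gives a number, while both compounds with allyl end at the same limit: the limit of > 100000 nM in this assay, at which 2 of the 3 values shown sit.

What the compounds shown leave open is whether the step follows the double bond of the allyl group or the longer chain, a question that a saturated propyl chain at this place would address. They also leave open how far the chlorine matters at all, which would take ethyl on the same core with hydrogen in place of the chlorine.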